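The compounds below may be only part of what the source reports. "The series", "measured", "known", "first", "only" and "open" are said of these compounds alone.

Measured so far:
Compound 1 `COc1ccc(-c2ccc3ncnc(N[C@H]4CCN(C(=O)C5CC5)C4)c3c2)cn1`: 500 nM
Compound 2 `COc1ncc(-c2ccc3ncnc(N[C@H]4CCN(C(=O)C5CCOCC5)C4)c3c2)cc1C#N`: 4550 nM

In a functional assay on SU-DHL-6 cells (Homo sapiens) for antiproliferative activity, read by CCK-8 assay, with a stated time of 72 h (on this read-out lower numbers stand for stronger inhibition and higher numbers for weaker inhibition), compound 2 gives 4550 nM, the higher of the two numbers and therefore the weaker inhibition. Its nearest neighbour on the scale is compound 1 at 500 nM, and the gap between the two lies beyond the usual scatter. The two compounds differ in more than one place, so this gap cannot be tied to any single structural feature.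

Compound 3 `COc1ncc(-c2ccc3ncnc(N[C@H]4CCN(C(=O)C5CCOCC5)C4)c3c2)cc1[N+](=O)[O-]` departs from compound 2 in one place only, with nitro in place of cyano on an aromatic carbon. The 5-cyano-6-methoxypyridin-3-yl group thus becomes 6-methoxy-5-nitropyridin-3-yl, while the rest of the molecule stays the same. For the measured compounds named here, no measured pair shows this exchange, so the data give no direction for it, and the expectation rests on compound 2 at 4550 nM. The expected outcome in this assay is no step beyond the scatter, and the estimate is a 1.1-fold lower number from compound 2 to compound 3 (0.06 log units; within the scatter). Compound 3 is expected at 4000 nM, with an estimated range from 1500 nM to 10000 nM.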

Compound 3, half-maximal inhibitory concentration: 5970 nM
Compound 3: middle estimate off by 1.5-fold (0.17 log units), on the low side; the measured number falls inside the stated range.
By their numbers in this assay, from the lowest: compound 1; then compounds 2 and 3 (each within the scatter of the next).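

At this position, on an aromatic carbon ortho to a methoxy group, nitro in place of cyano reads in this assay as a 1.3-fold higher number from compound 2 to compound 3 (0.12 log units; within the scatter), so the two groups cannot be told apart in this read-out. For the compounds shown here, this is the first comparison that isolates a single place, and it shows that moving from the 5-cyano-6-methoxypyridin-3-yl group to the 6-methoxy-5-nitropyridin-3-yl group, with 2 heavy atoms leaving and 3 entering and with 1 hydrogen-bond acceptor leaving and 2 entering, produces no step beyond the scatter. Nothing available gives a reason for this outcome.

Going by these compounds alone, whether an amine, a carboxylic acid or a plain hydrogen at this same aromatic carbon would also leave the number in place remains open, since cyano and nitro are the only two groups compared there. Compound 1 differs from compound 2 and from compound 3 in more than one place, so the compounds shown do not tie its lower number to any single feature, and they do not show whether nitro and cyano would also match each other alongside the rest of compound 1.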